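Fluoro for trifluoromethyl on a shared pyrimidine-free core description

The source may report more compounds than this note shows. Statements on the series, on what has been measured and on what is new or still open speak of the compounds shown alone.

Measured so far:
Compound 1, `O=C(Nc1cc(C(F)(F)F)cc(C(F)(F)F)c1)c1cnc(C(F)(F)F)nc1Cl`: > 10000 nM
Compound 2, `O=C(Nc1cc(C(F)(F)F)cc(C(F)(F)F)c1)c1cnc(C(F)(F)F)nc1C(F)(F)F`: > 10000 nM
Compound 3, `O=C(Nc1cc(C(F)(F)F)cc(C(F)(F)F)c1)c1cnc(C(F)(F)F)nc1`: > 10000 nM

In an assay on Jurkat cells for activation of nuclear factor NF-kappa-B complex (Homo sapiens) (on this read-out higher numbers stand for weaker inhibition and lower numbers for stronger inhibition), compound 2 gives only a limit, > 10000 nM, and not a number. Compound 1 likewise gives only a limit in this assay. Compound 3 also reaches only a limit there. Compound 2 therefore stands at the same limit as the other two values shown, (the limit of > 10000 nM in this assay, at which 3 of the 3 values shown sit).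

The unmeasured compound 4, `O=C(Nc1cc(C(F)(F)F)cc(C(F)(F)F)c1)c1cnc(F)nc1C(F)(F)F`, differs from compound 2 by fluoro in place of trifluoromethyl on an aromatic carbon.

The steps measured among compounds 1, 2 and 3 all bear on changes at this same aromatic carbon. The step that the two limits leave unreadable from compound 1 to compound 2, the step that the two limits leave unreadable from compound 1 to compound 3 and the step that the two limits leave unreadable from compound 2 to compound 3 each remain unreadable, since both ends sit at the limit. No measured step therefore gives a size or a direction for exchanging one small group for another at this carbon, and nothing shown suggests a move away from the limit. The step that the limit leaves unreadable from compound 2 to compound 4 is accordingly expected to stay within the scatter. Compound 4 is expected to give 20000 nM in this assay, within a range from 8000 nM to 60000 nM, most likely again reported only as a limit.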

Compound 4, half-maximal inhibitory concentration: 400 nM
The estimate for compound 4 lay 50-fold (1.70 log units) above the measured number, and the stated range ends above it.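

For the compounds shown here, replacing trifluoromethyl with fluoro on the aromatic carbon between two ring nitrogen atoms gives the first readable change in this assay, an at least 25-fold lower number from compound 2 to compound 4 (1.39 log units; beyond the scatter). The steps among compounds 1, 2 and 3 cannot be read, and they concern another aromatic carbon, while all three compounds carry trifluoromethyl at the carbon changed here. The result therefore shows that this position can move the read-out well beyond the scatter, and that compound 4 alone, among the compounds shown, has left the shared limit: the limit of > 10000 nM in this assay, at which 3 of the 4 values shown sit.

The compounds shown leave open whether the gain depends on fluoro itself or would follow from removing trifluoromethyl at this carbon, a question that hydrogen, chloro, a methyl group, a methoxy group or an amine there could address. They also leave open whether, with fluoro in place, the other aromatic carbon becomes readable, for example when its trifluoromethyl gives way to chloro or hydrogen, since that exchange has so far been seen only between limits.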